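The compounds below may be only part of what the source reports. "The series", "measured", "known", "first", "only" and "open" are said of these compounds alone.

Of the compounds shown here, two have been measured in a functional assay on MCF7 cells (Homo sapiens) for inhibition, read by sulforhodamine B assay, with a stated time of 48 h; on this read-out lower numbers stand for higher toxicity in this test and higher numbers for lower toxicity in this test. Compound 1 `COc1ccc(-c2cc(/C=C/C(=O)c3ccc(N)cc3)[nH]n2)cc1` gives 34100 nM in this assay. Compound 2 `COc1cc(-c2cc(/C=C/C(=O)c3ccc(N)cc3)[nH]n2)cc(OC)c1OC`, which carries two further methoxy groups on the same ring, gives 60500 nM in this assay. These two numbers lie within the usual scatter of each other, so neither compound can be set above the other on the evidence shown, and compound 2 is simply one of two closely similar values.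

Compound 3 `COc1ccc(-c2cc(/C=C/C(=O)c3ccc(N)cc3)[nH]n2)cc1OC` has not yet been measured. Its difference from compound 2 is hydrogen in place of methoxy on an aromatic carbon. Among the compounds with values here, as no measured pair isolates this change, a step of this kind from compound 2 to compound 3 is expected to stay within the scatter, in no clear direction, with a 1.3-fold lower number from compound 2 to compound 3 (0.13 log units; within the scatter) as the estimate. Compound 3 is therefore expected to give about 45000 nM in this assay, within a range of 15000 nM to 130000 nM.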

Compound 3, concentration lethal to 50% of the cells: 71200 nM
Compound 3: the middle estimate sits 1.6-fold (0.20 log units) below what was measured; measured number inside the range.
By their numbers in this assay, from the lowest: compounds 1, 2 and 3 (each within the scatter of the next, the first and the last beyond it).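

In this assay, hydrogen in place of methoxy on this aromatic carbon, ortho to a methoxy group and meta to a large group, gives a 1.2-fold higher number from compound 2 to compound 3 (0.07 log units; within the scatter), so this change leaves the number within the scatter. Methoxy in place of hydrogen on an aromatic carbon gives a 2.1-fold higher number from compound 1 to compound 3 (0.32 log units; beyond the scatter), a modest step and the first one in this series to lie beyond the scatter, towards lower toxicity in this test. Nothing shown bears on the reason for either step.

The compounds shown carry only hydrogen or methoxy at this position, so the effect of a hydroxy group, a fluorine atom or an amine there remains open. From the compounds shown here alone, whether the modest step would recur on another core also remains open.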